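Trading a Dimethylphenyl Amide for a Methoxyphenyl Amide

A few compounds are considered here, and "the series" means these few. Any claim that something is new, unique, unknown or untested is made for them only; others in the source may bear on it.

Measured so far:
Compound 1, `O=C(/C=C/C(=O)N1C/C(=C\c2ccccc2)C(=O)/C(=C/c2ccccc2)C1)Nc1ccc(Cl)c(Cl)c1`, gives 7500 nM in a functional assay on L1210 cells (Mus musculus) for cytotoxicity; a lower number here means a stronger inhibitor, a higher number a weaker inhibitor.
Compound 2, `Cc1ccc(NC(=O)/C=C/C(=O)N2C/C(=C\c3ccccc3)C(=O)/C(=C/c3ccccc3)C2)cc1C`, gives 31000 nM.

Among the measured compounds shown here, compound 2 has the highest number of the two; the only step, a 4.1-fold higher number from compound 1 to compound 2 (0.62 log units; beyond the scatter), was modest but beyond the scatter. Compound 3, `COc1ccc(NC(=O)/C=C/C(=O)N2C/C(=C\c3ccccc3)C(=O)/C(=C/c3ccccc3)C2)cc1`, carries 4-methoxyphenyl in place of 3,4-dimethylphenyl on an amide-type nitrogen. For the measured compounds named here, no measured step involves a methoxyphenyl group, so the single step from compound 1 to compound 2 gives only a loose guide. Compound 3 is therefore expected to stay near compound 2, a step of a 1.2-fold lower number from compound 2 to compound 3 (0.09 log units; within the scatter), estimated at 25000 nM with a range from 8000 nM to 80000 nM.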

Compound 3, half-maximal inhibitory concentration: 6800 nM
Compound 3: the middle estimate sits 3.7-fold (0.57 log units) above what was measured; measured number below the stated range.
By their numbers in this assay, from the lowest: compounds 3 and 1 (each within the scatter of the next); then compound 2.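

Swapping the 3,4-dimethylphenyl for a 4-methoxyphenyl on the amide-type nitrogen in this assay gives a clear change (a 4.6-fold lower number from compound 2 to compound 3 (0.66 log units; beyond the scatter)), so this position responds to the group it carries. The 4-methoxyphenyl and 3,4-dichlorophenyl groups cannot be told apart (a 1.1-fold lower number from compound 1 to compound 3 (0.04 log units; within the scatter)), which leaves compound 2 alone with the higher number. Nothing measured here explains why these groups differ or match.

Still open, as far as these compounds go, is where a plain phenyl, a group with a single methyl or chlorine, or a dimethylamino group would fall. From the compounds shown here alone, whether such groups would match compound 2 or compound 3 remains unknown.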